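The compounds below may be only part of what the source reports. "The series", "measured", "known", "first", "only" and "open" are said of these compounds alone.

Working notes on the amine series. Three compounds sharing one core have numbers in a functional assay on Caco-2 cells (Homo sapiens) for inhibition, read by MTT assay, with a stated time of 48 h, tested at 10 uM; a lower number here means less inhibition of growth, a higher number more inhibition of growth at the concentration tested: compound 1 (`CCN(CC)Cc1c(O)c([C@H]2CCN(C)C[C@H]2O)c2oc(C)cc(=O)c2c1O`) gives 17%, compound 2 (`Cc1cc(=O)c2c(O)c(CN3CCCC3)c(O)c([C@H]3CCN(C)C[C@H]3O)c2o1`) gives 22%, and compound 3 (`Cc1cc(=O)c2c(O)c(CN(C(C)C)C(C)C)c(O)c([C@H]3CCN(C)C[C@H]3O)c2o1`) gives 22%. Compound 3 stands level with compound 2, and compound 1 lies within the scatter of both.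

The step under review leads from compound 3 to compound 4 (`Cc1cc(=O)c2c(O)c(CN3CC(O)CC3C(=O)O)c(O)c([C@H]3CCN(C)C[C@H]3O)c2o1`): 2-carboxy-4-hydroxypyrrolidin-1-yl in place of diisopropylamino on a saturated chain carbon bound to an aromatic carbon. In words, 2-carboxy-4-hydroxypyrrolidin-1-yl comes in place of diisopropylamino on a saturated chain carbon bound to an aromatic carbon.

Within the data shown here, three measured steps bear on this change, all at the same place: a number 5 percentage points higher from compound 1 to compound 2 (within the scatter), a number 5 percentage points higher from compound 1 to compound 3 (within the scatter) and no change at the digits printed from compound 2 to compound 3 (within the scatter). All three lie within the scatter, so no exchange of amine so far has separated the compounds in this assay. On these data alone, none of them brings in a carboxy or a hydroxy group, however, so the entering group remains untested and the range is kept wide.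

The expected change is a number 4 percentage points lower from compound 3 to compound 4 (within the scatter), which is no step beyond the scatter. The estimate for compound 4 is 18%, with an expected range of 5% to 30%.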

Compound 4, percent growth inhibition at one concentration: 19%
Compound 4: middle estimate off by 1 percentage points, on the low side; low and high end bracket the measured number.
By their numbers in this assay, from the lowest: compounds 1, 4, 2 and 3 (each within the scatter of the next).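

In this assay, the first amine carrying a carboxy and a hydroxy group lies within the scatter of all three earlier amines: a number 3 percentage points lower from compound 3 to compound 4 (within the scatter), a number 3 percentage points lower from compound 2 to compound 4 (within the scatter) and a number 2 percentage points higher from compound 1 to compound 4 (within the scatter). The earlier steps shown here exchanged only diethylamino, pyrrolidin-1-yl and diisopropylamino, whereas this one shows that a saturated chain carbon bound to an aromatic carbon can also carry 2-carboxy-4-hydroxypyrrolidin-1-yl, with 2 hydrogen-bond donors and 3 hydrogen-bond acceptors against 0 and 1 for diisopropylamino, without a step beyond the scatter. No measurement at hand gives a cause for this result.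

The carboxy and hydroxy groups enter together, so the shown compounds cannot separate them, and a pyrrolidine carrying only a carboxylic acid or only a hydroxy group would be needed to read each alone. Also open, on these data alone, is whether another amine, such as morpholine or 4-methylpiperazine, or a longer chain carrying the amine, would produce any step beyond the scatter at this place.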